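Pyrimidine series: methyl to trifluoromethyl on compound 3

A few compounds are considered here, and "the series" means these few. Any claim that something is new, unique, unknown or untested is made for them only; others in the source may bear on it.

Three compounds of the series have been run in an assay on blood for inhibition of Indoleamine 2,3-dioxygenase 1 (Homo sapiens); a lower number here means a stronger inhibitor, a higher number a weaker inhibitor. Compound 1 `O=C(c1cccc(Cl)c1)N1CCCC2CC(C3(C(=O)Nc4ccc(F)cc4)CCC3)CCC21` gives 123 nM. Compound 2 `O=C(C1CC1)N1CCCC2CC(C3(C(=O)Nc4ccc(F)cc4)CCC3)CCC21` gives 15 nM, and compound 3 `Cc1nccc(N2CCCC3CC(C4(C(=O)Nc5ccc(F)cc5)CCC4)CCC32)n1` gives 10 nM. Compound 3 stands at the lowest of the three numbers; the step of a 12-fold lower number from compound 1 to compound 3 (1.09 log units; beyond the scatter) lies beyond the scatter, whereas the step of a 1.5-fold lower number from compound 2 to compound 3 (0.18 log units; within the scatter) lies within it, so compound 2 and compound 3 are not separable on these data. The step of an 8.2-fold lower number from compound 1 to compound 2 (0.91 log units; beyond the scatter) likewise lies beyond the scatter.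

Compound 4 `O=C(Nc1ccc(F)cc1)C1(C2CCC3C(CCCN3c3ccnc(C(F)(F)F)n3)C2)CCC1` differs from compound 3 in one place: trifluoromethyl in place of methyl on an aromatic carbon. For the measured compounds named here, no measured step covers this change; the steps from compound 1 and compound 2 to compound 3 replace the whole substituent on the ring amine nitrogen, not a group on the pyrimidine. The only bearing they have is that both carriers of a carbonyl on that nitrogen sit at higher numbers than compound 3, and compound 4 keeps the pyrimidine. In the absence of a direct precedent, the expectation is a step of no size beyond the scatter, a 1.2-fold higher number from compound 3 to compound 4 (0.08 log units; within the scatter). Compound 4 is therefore expected to give about 12 nM, in the range 4 nM to 40 nM.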

Compound 4, half-maximal inhibitory concentration: 48 nM
Estimate against measurement, compound 4: 4.0-fold (0.60 log units) below, and the stated range ends below it.
By their numbers in this assay, from the lowest: compounds 3 and 2 (each within the scatter of the next); then compound 4; then compound 1.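

Working notes: in this assay, the aromatic carbon between two ring nitrogen atoms is not a silent position on the pyrimidine, as the exchange of methyl for trifluoromethyl gives a 4.8-fold higher number from compound 3 to compound 4 (0.68 log units; beyond the scatter). The choice of group at this carbon also decides how the pyrimidine compares with the amides: with trifluoromethyl it no longer matches the cyclopropylcarbonyl, giving a 3.2-fold higher number from compound 2 to compound 4 (0.51 log units; beyond the scatter), although it still compares favourably with the (3-chlorophenyl)carbonyl, giving a 2.6-fold lower number from compound 1 to compound 4 (0.41 log units; beyond the scatter). No measurement at hand accounts for the rise in the number at this position.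

The compounds shown hold only methyl and trifluoromethyl at this carbon, so it stays open whether hydrogen, a methoxy group or an amine there would sit nearer compound 3 or nearer compound 4. Also open, as far as these compounds go, is whether the exchange of methyl for trifluoromethyl gives a step of similar size when another part of the shared core is changed, since the reading rests on a single pair.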